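The compounds below may be only part of what the source reports. "The series", "measured", "known", "first", "only" and "open" are said of these compounds alone.

Three measured compounds share one core and differ only in the group carried on the outer aromatic ring. Compound 1 `CN(C)Cc1ccc(/C=N/Nc2ncnc3sc(C(C)(C)C)cc23)cc1` gives 0.128 ug/mL in a functional assay on HCT-116 cells (Homo sapiens) for cytotoxicity, read by MTT assay, with a stated time of 3 days; on this read-out lower numbers stand for stronger inhibition and higher numbers for weaker inhibition. Compound 2 `CC(C)(C)c1cc2c(N/N=C/c3ccc(C(=O)O)cc3)ncnc2s1` gives 9.99 ug/mL in this assay, and compound 3 `CC(C)(C)c1cc2c(N/N=C/c3ccc(CO)cc3)ncnc2s1` gives 0.665 ug/mL. Compound 3 thus stands second highest of the three numbers: a 15-fold lower number from compound 2 to compound 3 (1.18 log units; beyond the scatter), while a 5.2-fold higher number from compound 1 to compound 3 (0.72 log units; beyond the scatter). The step of interest leads to compound 4 `CC(C)(C)c1cc2c(N/N=C/c3ccc(O)cc3)ncnc2s1`, in which (hydroxy in place of hydroxymethyl on an aromatic carbon). Among the compounds with values here, no measured step exchanges these two groups, so the nearest guide is how the read-out moves when the group on that aromatic carbon is changed at all: a 78-fold higher number from compound 1 to compound 2 (1.89 log units; beyond the scatter), a large effect, and the modest step already noted between compound 1 and compound 3. Both indicate that this position matters, but neither points clearly in one direction for a hydroxy. Compound 4 is therefore expected to show a 1.8-fold higher number from compound 3 to compound 4 (0.26 log units; within the scatter), a modest rise in the number. Compound 4 is estimated at 1.2 ug/mL, with a range from 0.35 ug/mL to 4 ug/mL.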

Compound 4, half-maximal inhibitory concentration: 0.844 ug/mL
The estimate for compound 4 lay 1.4-fold (0.15 log units) above the measured number; the range from low to high includes it.
By their numbers in this assay, from the lowest: compound 1; then compounds 3 and 4 (each within the scatter of the next); then compound 2.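

In this assay, exchanging hydroxymethyl for hydroxy on this aromatic carbon gives a 1.3-fold higher number from compound 3 to compound 4 (0.10 log units; within the scatter), so removing the chain carbon leaves the two groups indistinguishable on this read-out. The hydroxy group also takes the same place among the other substituents as hydroxymethyl, with a 12-fold lower number from compound 2 to compound 4 (1.07 log units; beyond the scatter) on one side and a 6.6-fold higher number from compound 1 to compound 4 (0.82 log units; beyond the scatter) on the other. No measurement available here explains the sizes of these steps.

The compounds shown leave open whether a primary amine set directly on the aromatic ring, a methoxy group or a longer chain ending in hydroxy would fall with compounds 3 and 4 or nearer to compound 1. They also do not show whether a methyl ester or a primary amide at this place would keep the gap seen with the carboxy group.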